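Acetoxymethyl replaces methylcarbamoyl on the piperidine side chain

This account rests on a few compounds, and the source may have more. Where it says the series, first, only, none or still open, it means among the compounds named here.

Measured so far:
compound 1, `Cn1ncc(Cl)c1-c1cc(C(=O)N[C@@H]2CN[C@H](CCNS(C)(=O)=O)C[C@H]2c2ccc(F)c(F)c2)oc1Cl`, 3.29 nM
compound 2, `CNC(=O)C[C@@H]1C[C@@H](c2ccc(F)c(F)c2)[C@H](NC(=O)c2cc(-c3c(Cl)cnn3C)c(Cl)o2)CN1`, 1.37 nM

In an assay for inhibition of RAC-alpha serine/threonine-protein kinase (Homo sapiens), read by HTRF, with a stated time of 1 h (a higher number here means a weaker inhibitor, a lower number a stronger inhibitor), compound 2 holds the lowest of the two numbers, with compound 1 as its nearest neighbour. Among the measured compounds shown here, the only measured step, a 2.4-fold lower number from compound 1 to compound 2 (0.38 log units; beyond the scatter), concerns the same chain position. Compound 3, `CC(=O)OCC[C@@H]1C[C@@H](c2ccc(F)c(F)c2)[C@H](NC(=O)c2cc(-c3c(Cl)cnn3C)c(Cl)o2)CN1`, carries the change (acetoxymethyl in place of methylcarbamoyl on a saturated chain carbon bound to a saturated ring carbon), and the hydrogen-bond donor of compound 2 is lost. For the measured compounds named here, no measured step covers this exchange, so only a modest shift is expected, likely weakening; the step is estimated as a 2.6-fold higher number from compound 2 to compound 3 (0.41 log units; beyond the scatter). For compound 3 the expected value is 3.5 nM, within 1.2 nM to 12 nM.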

Compound 3, half-maximal inhibitory concentration: 3.4 nM
Compound 3: middle estimate off by 1.0-fold (0.01 log units), on the high side; the range from low to high includes it.
By their numbers in this assay, from the lowest: compound 2; then compounds 1 and 3 (each within the scatter of the next).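

In this assay this position responds modestly to the exchange of methylcarbamoyl for acetoxymethyl, with a 2.5-fold higher number from compound 2 to compound 3 (0.39 log units; beyond the scatter) in this series. The ester side chain and the methanesulfonamido side chain cannot be told apart, with a 1.0-fold higher number from compound 1 to compound 3 (0.01 log units; within the scatter) here, so among these three compounds only compound 2 stands apart. Nothing available explains this difference. Still open, on these data alone, is whether a primary amide, an amine or a carboxylic acid at the end of this chain, or a longer chain, would match compound 2.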